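Swapping the Ring on the Thiocarbonyl of Compound 2

A few compounds are considered here, and "the series" means these few. Any claim that something is new, unique, unknown or untested is made for them only; others in the source may bear on it.

compound 1 `N/C(=N\NC(=S)N1CCOCC1)c1ccc(F)cn1`: 86.2%
compound 2 `N/C(=N\NC(=S)N1CCOCC1)c1ccccn1`: 14%
compound 3 `Cc1ccnc(/C(N)=N/NC(=S)N2CCOCC2)c1`: 90.6%

In a functional assay on A-375 cells (Homo sapiens) for cytotoxicity, read by MTT assay, with a stated time of 72 h, tested at 100 uM (a lower number here means less inhibition of growth, a higher number more inhibition of growth at the concentration tested), compound 2 stands lowest of the three. The step of a number 72.2 percentage points lower from compound 1 to compound 2 (beyond the scatter) and the step of a number 76.6 percentage points higher from compound 2 to compound 3 (beyond the scatter) are both large and both set compound 2 far below its two neighbours.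

Compound 4 `N/C(=N\NC(=S)N1CCCC1)c1ccccn1` differs from compound 2 by pyrrolidin-1-yl in place of morpholin-4-yl on a thiocarbonyl carbon. The two measured steps each concern a substituent on an aromatic carbon, not the group on the thiocarbonyl carbon, so neither bears directly on this change, and the data offer no guide to its size. With nothing to support a shift either way, the step of a number 6 percentage points higher from compound 2 to compound 4 (within the scatter) is expected to stay within the scatter. Compound 4 is therefore estimated to give about 20%, somewhere between 5% and 50%.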

Compound 4, percent growth inhibition at one concentration: 87.8%
The estimate for compound 4 lay 67.8 percentage points below the measured number; the measured number lies above the stated range.
By their numbers in this assay, from the lowest: compound 2; then compounds 1, 4 and 3 (each within the scatter of the next).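

In this assay, among the compounds shown here, replacing morpholin-4-yl with pyrrolidin-1-yl on the thiocarbonyl carbon gives a number 73.8 percentage points higher from compound 2 to compound 4 (beyond the scatter), so this place, untouched by the earlier steps, also carries a large step. The change swaps a six-membered ring with 2 hetero atoms for a five-membered ring with 1 hetero atom, and these compounds cannot separate ring size from loss of the oxygen. Nothing available explains the step. Open, on these data alone, is whether piperidin-1-yl, which keeps the six-membered ring without the oxygen, would give a high or a low number, and whether pyrrolidin-1-yl combines with fluoro or methyl on the aromatic carbon.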